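The source may hold more compounds than are shown below. What is called first, only, known or untested is meant among the compounds shown, and "the series" means these compounds.

Measured compounds:
- compound 1 `CCCSc1ccc2[nH]c(NC(=O)OCCCN(C)C)nc2c1`: 78.3%
- compound 2 `CN(C)CCCOC(=O)Nc1nc2cc(C(=O)c3ccc(F)cc3)ccc2[nH]1`: 86.6%

Within the data shown here, in a functional assay on PC-3 cells (Homo sapiens) for cytotoxicity, read by MTT assay, with a stated time of 72 h, tested at 10 uM (on this read-out higher numbers stand for a weaker effect at the one concentration tested and lower numbers for a stronger effect), compound 1 gives 78.3% and compound 2 gives 86.6%; the one step that joins them, a number 8.3 percentage points higher from compound 1 to compound 2 (within the scatter), replaces a group on the aromatic part of the shared core and lies within the scatter. Compound 1 has the lower of the two numbers, but the gap to compound 2 does not separate them.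

Compound 3 `CCCSc1ccc2[nH]c(NC(=O)OCC3(C)COC3)nc2c1` has not been measured in this assay. It differs from compound 1 in the ester part of the carbamate: 3-methyloxetan-3-yl in place of 2-(dimethylamino)ethyl on a saturated chain carbon bound to an oxygen next to a carbonyl group. Among the measured compounds shown here, no measured step touches that part of the molecule, so the only step available, a number 8.3 percentage points higher from compound 1 to compound 2 (within the scatter), bears on it at most by showing that the two measured numbers sit close together. No step beyond the scatter is therefore expected in this assay in either direction, and the estimate for compound 3 is 80% with a range of 62% to 96%, which corresponds to an expected step of a number 1.7 percentage points higher from compound 1 to compound 3 (within the scatter).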

Compound 3, a percentage reported as activity, at one concentration (the size of the read-out at that concentration, not a potency): 79.3%
For compound 3 the middle estimate is 0.7 percentage points above the measured one, within the range that was stated.
By their numbers in this assay, from the lowest: compounds 1, 3 and 2 (each within the scatter of the next).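

The ester part of the carbamate now has a step of its own in this assay: the change from 2-(dimethylamino)ethyl to 3-methyloxetan-3-yl gives a number 1 percentage points higher from compound 1 to compound 3 (within the scatter) on the saturated chain carbon bound to an oxygen next to a carbonyl group. With the propylsulfanyl group held fixed, this exchange of a chain carrying the dimethylamino group for a four-membered non-aromatic ring therefore leaves the read-out within the scatter, so the result does not separate the two groups. Nothing available offers an explanation for how closely these two compounds read.

Still open, from the compounds shown here alone, is whether a carboxylic acid or a longer chain in this ester part would give a step beyond the scatter. Also open, going by these compounds, is whether 3-methyloxetan-3-yl would read the same way with the (4-fluorophenyl)carbonyl group on the core.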